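A few compounds are considered here, and "the series" means these few. Any claim that something is new, unique, unknown or untested is made for them only; others in the source may bear on it.

Measured compounds:
Compound 1 `CC[C@H](C)[C@H]1C(=O)N[C@H](Cc2ccc(O)c(Br)c2)C(=O)N[C@@H](C(C)(C)O)C(=O)O[C@H](c2ccccc2)[C@H](C)/C=C/C=C(\C)[C@H](OC)C/C=C(\C)C(=O)N1C` gives 5.21 nM in a functional assay on HepG2 cells (Homo sapiens) for antiproliferative activity; a higher number here means a weaker inhibitor, a lower number a stronger inhibitor.
Compound 2 `CC[C@H](C)[C@H]1C(=O)N[C@H](Cc2cc(Cl)c(O)c(Cl)c2)C(=O)N[C@@H](C(C)C)C(=O)O[C@H](c2ccccc2)[C@H](C)/C=C/C=C(\C)[C@H](OC)C[C@@H]2O[C@@]2(C)C(=O)N1C` gives 5.65 nM in this assay.

Compound 2 stands at the higher of the two numbers, and its nearest neighbour is compound 1, whose number is lower by an amount that falls within the scatter of this assay. The two compounds differ in several places at once, so their pair shows only that both sit close together.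

Compound 3 `CC[C@H](C)[C@H]1C(=O)N[C@H](Cc2cc(Cl)c(O)c(Cl)c2)C(=O)N[C@@H](C(C)(C)O)C(=O)O[C@H](c2ccccc2)[C@H](C)/C=C/C=C(\C)[C@H](OC)C[C@@H]2O[C@@]2(C)C(=O)N1C` has not been measured. It differs from compound 2 in one place: hydroxy in place of hydrogen on a saturated chain carbon bound to two saturated chain carbons and a saturated ring carbon Compound 1 already carries the 1-hydroxy-1-methylethyl group within a different surround and gives 5.21 nM, a number close to that of compound 2. Among the compounds with values here, no step between measured compounds isolates this change, so no direction can be read from the data. The account therefore expects the step of a 1.0-fold lower number from compound 2 to compound 3 (0.01 log units; within the scatter) to stay within the scatter. Compound 3 is estimated to give 5.5 nM, with a range from 2.2 nM to 14 nM.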

Compound 3, half-maximal inhibitory concentration: 3.36 nM
Beside the measured number, compound 3's estimate is 1.6-fold (0.21 log units) above it; the range from low to high includes it.
By their numbers in this assay, from the lowest: compounds 3, 1 and 2 (each within the scatter of the next).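

In this assay, within the data shown here, the change from isopropyl to 1-hydroxy-1-methylethyl is now isolated for the first time, on a core that otherwise stays the same, and it reads a 1.7-fold lower number from compound 2 to compound 3 (0.23 log units; within the scatter). The earlier pair differed in several places at once and could not speak to this group alone; this step shows that hydroxy in place of hydrogen on this saturated chain carbon leaves the number within the scatter, so this position carries either group without a difference the assay can resolve. Nothing available bears on the reason for this result.

As far as these compounds go, whether an amine or a carboxylic acid on this carbon would also stay within the scatter remains open. So does whether the same change would read alike on the surround of compound 1.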